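Tert-butyl in place of chloro: compound 2 to compound 4

A few compounds are considered here, and "the series" means these few. Any claim that something is new, unique, unknown or untested is made for them only; others in the source may bear on it.

Compound 1 `O=C1N/C(=N\Cc2ccc(C(F)(F)F)cc2)S/C1=C1/CCNC(=O)c2[nH]ccc21`: > 100000 nM (a limit)
Compound 2 `O=C1N/C(=N\Cc2ccc(Cl)cc2)S/C1=C1/CCNC(=O)c2[nH]ccc21`: > 100000 nM (a limit)
Compound 3 `O=C1N/C(=N\Cc2ccccc2Cl)S/C1=C1/CCNC(=O)c2[nH]ccc21`: > 100000 nM (a limit)

All three entries come from a functional assay on SK-MEL-28 cells (Homo sapiens) for inhibition, read by MTT assay, with a stated time of 48 h; a lower number here means a stronger inhibitor, a higher number a weaker inhibitor. Compound 2 stands at > 100000 nM, which is a limit of the assay and not a number. No ranking of the measured compounds can be read from these results: the limit of > 100000 nM in this assay, at which 3 of the 3 values shown sit.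

Compound 4 `CC(C)(C)c1ccc(C/N=C2\NC(=O)/C(=C3\CCNC(=O)c4[nH]ccc43)S2)cc1` has tert-butyl in place of chloro on an aromatic carbon, para to a large group, relative to compound 2: tert-butyl in place of chloro on an aromatic carbon. The closest measured change is also a replacement on an aromatic carbon: a step that the two limits leave unreadable from compound 1 to compound 2. The other measured change is 2-chlorophenyl in place of 4-chlorophenyl: a step that the two limits leave unreadable from compound 2 to compound 3. For the measured compounds named here, neither gives a size that can be carried over, so no step of a particular size or direction is expected in this assay. The expected outcome is that the new compound again reports only a limit, and the step that the estimate means, a number no higher from compound 2 to compound 4 (the limit leaves the size open), is expected to carry no readable change. For compound 4 the estimated value is 100000 nM, with an expected range from 30000 nM to 200000 nM.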

Compound 4, half-maximal inhibitory concentration: 23500 nM
The estimate for compound 4 lay 4.3-fold (0.63 log units) above the measured number, outside the stated range (below it).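

Replacing chloro with tert-butyl on the aromatic carbon para to a large group gives an at least 4.2-fold lower number from compound 2 to compound 4 (0.62 log units; beyond the scatter) in this assay and replacing trifluoromethyl there gives an at least 4.2-fold lower number from compound 1 to compound 4 (0.62 log units; beyond the scatter) as the second readable change at this carbon. This shows that the read-out can respond to the group at this position, with tert-butyl, which has 4 heavy atoms in place of the 1 heavy atom of chloro, moving the series off the limit. For the compounds shown here, the steps among the earlier compounds cannot be read, so they could not show this: the limit of > 100000 nM in this assay, at which 3 of the 4 values shown sit.

Both readable steps give only a lower bound on the size of the change, and tert-butyl is a single example, so no trend across groups at this carbon can yet be drawn. Open is whether an amine, a carboxylic acid or a longer alkyl chain on the same aromatic carbon would lower the number in this assay further, leave it unchanged or return it to the limit, and how much of the response depends on the shared core, which stays constant across all the compounds shown.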